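Aryl urea series: compound 4 expectation from compound 1

The compounds below may be only part of what the source reports. "The series", "measured", "known", "first", "only" and "open" are said of these compounds alone.

Measured so far:
compound 1 `O=C(Nc1ccc(Cl)cc1)Nc1cccc(CNc2nccnc2Cl)c1` — 5470 nM
compound 2 `CC(C)(C)c1ccc(NC(=O)Nc2cccc(CNc3nccnc3Cl)c2)cc1` — 6010 nM
compound 3 `O=C(Nc1ccc(C(F)(F)F)cc1)Nc1cccc(CNc2nccnc2Cl)c1` — 4580 nM

All three numbers come from a functional assay on T-24 cells (Homo sapiens) for antiproliferative activity, read by MTT assay, with a stated time of 48 h; a higher number here means a weaker inhibitor, a lower number a stronger inhibitor. Compound 1 stands second highest of the three; its nearest neighbour is compound 2, with a 1.1-fold higher number from compound 1 to compound 2 (0.04 log units; within the scatter), and its furthest is compound 3, with a 1.2-fold lower number from compound 1 to compound 3 (0.08 log units; within the scatter). Between the other two the step is a 1.3-fold lower number from compound 2 to compound 3 (0.12 log units; within the scatter). Among the measured compounds shown here, every step so far lies within the scatter, so on these numbers the three compounds cannot be told apart in this assay.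

Compound 4 `Cc1cccc(NC(=O)Nc2cccc(CNc3nccnc3Cl)c2)c1` differs from compound 1 at the same position as the other two: 3-methylphenyl in place of 4-chlorophenyl on an amide-type nitrogen. The three steps that bear on it are all exchanges of one group on the aryl urea end, and none of them moved the number beyond the scatter. The expectation for this assay is therefore that compound 4 also gives a number close to that of compound 1, with a 1.0-fold higher number from compound 1 to compound 4 (0.00 log units; within the scatter) as the estimated step, no direction being favoured by the data. The estimate for compound 4 in this assay is 5500 nM, expected to fall between 2500 nM and 12000 nM.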

Compound 4, half-maximal inhibitory concentration: 9570 nM
For compound 4 the middle estimate is 1.7-fold (0.24 log units) below the measured one, and the stated range covers the measured number.
By their numbers in this assay, from the lowest: compounds 3, 1, 2 and 4 (each within the scatter of the next, the first and the last beyond it).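

In this assay, among the compounds shown here, 3-methylphenyl in place of 4-chlorophenyl on the amide-type nitrogen is the first exchange that alters both the substituent and its ring position, and it still stays within the scatter, with a 1.7-fold higher number from compound 1 to compound 4 (0.24 log units; within the scatter). The series now has a measurable spread at this position, though only at its two ends: compound 3 gives 4580 nM and compound 4 gives 9570 nM, and these two lie beyond the scatter of each other, while every neighbouring pair in the order remains within it. No measurement available here explains that spread.

Since compound 4 changes the substituent and its ring position together, the two changes cannot be separated, and 4-methylphenyl or 3-chlorophenyl on the same nitrogen would be needed to tell them apart. Also open is whether any group on this ring moves the number clearly beyond the scatter from compound 1, for instance a carboxylic acid or an amine, since all the groups shown so far are carbon or halogen substituents.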